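Varying the acyl group on a shared core

The source may report more compounds than this note shows. Statements on the series, on what has been measured and on what is new or still open speak of the compounds shown alone.

Three compounds share one core and differ only in the group on the carbonyl carbon whose other neighbours are oxygen next to a carbonyl group. In an ADME assay on HepG2 2.2.15 cells (Homo sapiens) for cytotoxicity (on this read-out higher numbers stand for lower toxicity in this test and lower numbers for higher toxicity in this test), compound 1 `COCC(=O)OCCc1c(-c2ccccc2Cl)c2cc(Cl)ccc2[nH]c1=O` gives 74000 nM. In this assay compound 2 `CC(=O)N1CCC(C(=O)OCCc2c(-c3ccccc3Cl)c3cc(Cl)ccc3[nH]c2=O)CC1` gives 82000 nM, and compound 3 `O=C(OCCc1c(-c2ccccc2Cl)c2cc(Cl)ccc2[nH]c1=O)c1ccco1` gives 98000 nM. Compound 3 holds the highest of the three numbers, though every gap lies within the scatter: its nearest neighbour is compound 2, with a 1.2-fold higher number from compound 2 to compound 3 (0.08 log units; within the scatter), its furthest is compound 1, with a 1.3-fold higher number from compound 1 to compound 3 (0.12 log units; within the scatter), and a 1.1-fold higher number from compound 1 to compound 2 (0.04 log units; within the scatter) is likewise within the scatter. Compound 4 `COc1ccc(/C=C/C(=O)OCCc2c(-c3ccccc3Cl)c3cc(Cl)ccc3[nH]c2=O)cc1OC` has not been measured. It differs from compound 3 as follows: 2-(3,4-dimethoxyphenyl)ethenyl in place of furan-2-yl on a carbonyl carbon. Among the compounds with values here, no measured step brings in this group, but each change made so far at this carbonyl carbon left this assay within the scatter, so no step beyond the scatter is expected in either direction. Compound 4 is therefore estimated at 85000 nM, with a range from 40000 nM to 180000 nM, which amounts to an expected 1.2-fold lower number from compound 3 to compound 4 (0.06 log units; within the scatter).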

Compound 4, half-maximal cytotoxic concentration: > 1200000 nM
Compound 4: a limit, no number; the forecaster's own chance of this, stated with the estimate: 20%; at least 14-fold (1.14 log units) between middle value and limit.
By their numbers in this assay, from the lowest: compounds 1, 2 and 3 (each within the scatter of the next). At a limit, above all of these: compound 4.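

At this carbonyl carbon, the group can move the number in this assay beyond the scatter, which the three earlier groups did not do: 2-(3,4-dimethoxyphenyl)ethenyl gives an at least 12-fold higher number from compound 3 to compound 4 (1.08 log units; beyond the scatter), an at least 14-fold higher number from compound 2 to compound 4 (1.16 log units; beyond the scatter) and an at least 16-fold higher number from compound 1 to compound 4 (1.20 log units; beyond the scatter). The value of compound 4 is a limit of the assay and not a number: the limit of > 1200000 nM in this assay, at which 1 of the 4 values shown sits. On this read-out, the steps point towards lower toxicity in this test, so methoxymethyl, 1-acetylpiperidin-4-yl and furan-2-yl do not represent everything this position allows.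

The change brings in a six-membered aromatic ring, a double bond and two methoxy groups at once, and the compounds shown do not separate their parts. A 2-phenylethenyl group without the methoxy groups, or a saturated 2-(3,4-dimethoxyphenyl)ethyl chain, would be needed to tell which part goes with the step.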